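Compound 3 Expected to Stay Near the Assay Limit

The source may hold more compounds than are shown below. What is called first, only, known or untested is meant among the compounds shown, and "the series" means these compounds.

Compound 1 `CCOC(=O)C1=Cc2ccccc2OC1(OCc1cc(-c2ccc(F)cc2F)no1)C(F)(F)F` was tested in a functional assay on DU-145 cells (Homo sapiens) for inhibition, read by MTT assay, with a stated time of 24 h (on this read-out lower numbers stand for stronger inhibition and higher numbers for weaker inhibition), and returned only a limit, > 150000 nM, rather than a number. The study also includes compound 2 `CCOC(=O)C1=Cc2ccccc2OC1(OCc1cn(-c2ccc(F)c([N+](=O)[O-])c2)nn1)C(F)(F)F`, which carries a different five-membered ring and aryl group; in this assay compound 2 gives 13200 nM. Compound 1 therefore stands at the weak end of what has been measured, with nothing more than a limit to describe it, as recorded in the limit of > 150000 nM in this assay, at which 1 of the 2 values shown sits.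

Compound 3 `CCOC(=O)C1=Cc2ccccc2OC1(OCc1cc(-c2ccc(Cl)cc2)no1)C(F)(F)F` has not yet been measured in this assay. It differs from compound 1 in one place: 4-chlorophenyl in place of 2,4-difluorophenyl on an aromatic carbon. No measured step of this kind exists among these compounds, so no size is known for it.

Exchanging one halogenated phenyl for another is expected to leave the compound close to where compound 1 stands, so the step of an at least 1.2-fold lower number from compound 1 to compound 3 (0.09 log units; that floor lies within the scatter) is expected to be small, with no direction claimed beyond the scatter. Compound 3 is therefore estimated to give 120000 nM in this assay, within a range from 40000 nM to 300000 nM, and it may again return only a limit.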

Compound 3, half-maximal inhibitory concentration: 18200 nM
For compound 3 the middle estimate is 6.6-fold (0.82 log units) above the measured one; the measured number lies below the stated range.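

Exchanging the aryl group on the five-membered aromatic ring with 1 nitrogen and 1 oxygen, with the rest of the core of compound 1 left as it stands, gives an at least 8.2-fold lower number from compound 1 to compound 3 (0.91 log units; beyond the scatter) in this assay. Among these compounds, this is the first step at this place, and it shows that the aromatic carbon next to the ring nitrogen is not indifferent to which halogenated phenyl it carries: a swap of 2,4-difluorophenyl for 4-chlorophenyl alone is enough to bring a number out of a compound that otherwise returned only a limit. The true size of the step remains unknown and what is printed is only its floor, because the starting point is a limit for compound 1 and not a number: the limit of > 150000 nM in this assay, at which 1 of the 3 values shown sits.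

The compounds shown leave open whether the gain follows from the loss of the two fluorine atoms, from the arrival of the chlorine, or from both, since the single exchange changes these together. They also leave open how far this place tolerates other groups, such as an unsubstituted phenyl, a 4-methoxyphenyl or a 4-aminophenyl.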